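Swapping an azetidine for an oxetanylmethoxy group

The source may report more compounds than this note shows. Statements on the series, on what has been measured and on what is new or still open speak of the compounds shown alone.

In a functional assay on cells for antagonist activity at Free fatty acid receptor 1 (Homo sapiens), read by TR-FRET and inositol phosphate accumulation, with a stated time of 2 h (on this read-out lower numbers stand for stronger inhibition and higher numbers for weaker inhibition), compound 3 `CC1(C#N)CN(c2cc(COc3ccc(F)c(F)c3F)nc(-c3ccccn3)n2)C1` gives 158 nM, the lowest of the two numbers recorded so far. Compound 2 `Cc1cc(COc2ccccc2F)nc(-c2ccccn2)n1` gives 398 nM, a higher number than that of compound 3, and the gap lies beyond the usual scatter. Compound 1 `CC(=O)Nc1ccc(OCc2cc(C)nc(-c3ccccn3)n2)cc1` is recorded only as a limit of this assay, > 39800 nM. That limit is the one noted in the limit of > 39800 nM in this assay, at which 1 of the 3 values shown sits. Compound 4 `CC1(COc2cc(COc3ccc(F)c(F)c3F)nc(-c3ccccn3)n2)COC1` has not yet been measured in this assay. It differs from compound 3 by (3-methyloxetan-3-yl)methoxy in place of 3-cyano-3-methylazetidin-1-yl on an aromatic carbon. The leaving and entering groups are of like size as counted, each built around a single four-membered ring with one hetero atom, while the nitrile of compound 3 is absent from compound 4. Among the measured compounds shown here, no pair of measured compounds shows this exchange, so no measured step guides the expectation. Compound 4 is expected to give about 250 nM, with a plausible range from 80 nM to 800 nM. The step this estimate means, a 1.6-fold higher number from compound 3 to compound 4 (0.20 log units; within the scatter), is expected to stay within the usual scatter in this assay.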

Compound 4, half-maximal inhibitory concentration: 79.4 nM
Estimate against measurement, compound 4: 3.1-fold (0.50 log units) above; the whole stated range lies above it.
By their numbers in this assay, from the lowest: compounds 4 and 3 (each within the scatter of the next); then compound 2. At a limit, above all of these: compound 1.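

In this assay, the exchange on an aromatic carbon next to the ring nitrogen gives a 2.0-fold lower number from compound 3 to compound 4 (0.30 log units; within the scatter), so the two groups cannot be told apart on this read-out. Among the compounds shown here, this is the first view of what this place accepts with the rest of the molecule held fixed: in this pair, neither the nitrile nor the azetidine is required to keep the number in this range, since (3-methyloxetan-3-yl)methoxy serves as well as 3-cyano-3-methylazetidin-1-yl. Nothing measured here offers a reason for this outcome. As far as these compounds go, the two groups both carry a four-membered ring, so whether that ring matters at this place remains open. An open-chain ether, a simple amine or a carboxylic acid on the same carbon would test this, and the pair gives no hint of how any of them would read.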